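The source may hold more compounds than are shown below. What is called first, only, known or untested is meant among the compounds shown, and "the series" means these compounds.

Three thiophene-based compounds built around the same core have been examined in an assay on CHO cells for displacement of a labelled ligand from adenosine receptor A3 (Homo sapiens), read by scintillation counting, tested at 10 uM; on this read-out higher numbers stand for more inhibition at the one concentration tested (going by the name of the read-out) and lower numbers for less inhibition. Compound 1 `CC(C)Cc1csc(N)c1C(=O)c1ccc(Cl)cc1` gives 1% in this assay. Compound 2 `CC(C)(C)c1csc(N)c1C(=O)c1ccc(Cl)cc1` gives 1%. Going by the values given here, the one step between measured compounds that differs in a single place, no change at the digits printed from compound 1 to compound 2 (within the scatter), shows no movement, and it concerns a group on the core rather than the position changed here. Compound 3 `CC(C)(C)Cc1c(-c2ccc(F)cc2F)sc(N)c1C(=O)c1ccc(Cl)cc1` gives 1% in this assay, so it stands level with compound 1 and compound 2 at the digits shown, the nearest being compound 1 and the furthest compound 2, both within the scatter.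

Compound 4 `COc1ccccc1-c1sc(N)c(C(=O)c2ccc(Cl)cc2)c1CC(C)(C)C` differs from compound 3 in one place: 2-methoxyphenyl in place of 2,4-difluorophenyl on an aromatic carbon. Among the compounds with values here, no measured step bears directly on exchange of the aryl group at that position of the core; the only step available, that from compound 1 to compound 2, was flat. With compound 3 giving 1% and every measured analogue sitting at the same level, compound 4 is expected to remain where compound 3 sits, with a step of a number 1 percentage points higher from compound 3 to compound 4 (within the scatter) that is not expected to exceed the scatter. Compound 4 is therefore estimated at 2% in this assay, within a range from 0% to 12%.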

Compound 4, a percentage reported as inhibition, at one concentration (the size of the read-out at that concentration, not a potency): 1%
Compound 4: middle estimate off by 1 percentage points, on the high side, within the range that was stated.
By their numbers in this assay, from the lowest: compounds 1, 2, 3 and 4 (each within the scatter of the next).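

Going by these compounds alone, the exchange on the aromatic carbon next to the ring sulfur gives the first direct reading at this place: in this assay, 2-methoxyphenyl in place of 2,4-difluorophenyl gives no change at the digits printed from compound 3 to compound 4 (within the scatter) on the shared core with the neopentyl group held constant. The entering group brings oxygen and the hydrogen-bond acceptor counted for it, while the leaving group brings fluorine and no such acceptor, yet this difference between the two aryl groups is not matched by any printed change at the one concentration tested, and the earlier step, no change at the digits printed from compound 1 to compound 2 (within the scatter) for tert-butyl in place of isobutyl, concerned a different group. Nothing in the available data accounts for this flat result.

From the compounds shown here alone, with all four compounds level, it stays open whether any group at this position can raise the inhibition read-out at all. An aminomethyl group, a carboxylic acid or a longer alkyl chain in place of the aryl ring, or a replacement of the amino group or the (4-chlorophenyl)carbonyl group, could each still give a different answer.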